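The source may report more compounds than this note shows. Statements on the series, on what has been measured and on what is new or still open speak of the compounds shown alone.

The series shares one core, seen in compound 1 `CCN1CCN(CC(=O)Nc2ccc(-c3nc(-c4ccccc4)c(-c4ccccc4)n3C)cc2)CC1`, which in a functional assay on MCF7 cells (Homo sapiens) for cytotoxicity, read by MTT assay, with a stated time of 24 h, tested at 32 ug/mL (on this read-out lower numbers stand for a weaker effect and higher numbers for a stronger effect at the one concentration tested), gives 38.6%. Compound 2 `CN(C)/C=C/N1CCN(CC(=O)Nc2ccc(-c3nc(-c4ccccc4)c(-c4ccccc4)n3C)cc2)CC1` gives 25.8% in this assay, and the step of a number 12.8 percentage points lower from compound 1 to compound 2 (beyond the scatter) is the only one in the set beyond the scatter. Compound 3 `Cn1c(-c2ccc(NC(=O)CN3CCN(Cc4ccccc4)CC3)cc2)nc(-c2ccccc2)c1-c1ccccc1` gives 33.6% in this assay; its number sits between those of compound 1 and compound 2, but both gaps lie within the scatter, as the steps of a number 5 percentage points lower from compound 1 to compound 3 (within the scatter) and a number 7.8 percentage points higher from compound 2 to compound 3 (within the scatter) show.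

Compound 4 `Cc1ccc(CN2CCN(CC(=O)Nc3ccc(-c4nc(-c5ccccc5)c(-c5ccccc5)n4C)cc3)CC2)cc1` differs from compound 3 by methyl in place of hydrogen on an aromatic carbon. Within the data shown here, no measured step touches the aromatic ring of the benzyl group itself; the two steps that reach the amine nitrogen in the ring, a number 5 percentage points lower from compound 1 to compound 3 (within the scatter) and a number 7.8 percentage points higher from compound 2 to compound 3 (within the scatter), exchange the whole substituent there and still remain within the scatter. The present change is smaller than either of those, so no step beyond the scatter is expected in this assay. Compound 4 is therefore expected to give about 34%, within 22% to 46%. The step of a number 0.4 percentage points higher from compound 3 to compound 4 (within the scatter) is expected to be flat, and a measured number inside the scatter of compound 3 would be the unsurprising outcome.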

Compound 4, a percentage reported as activity, at one concentration (the size of the read-out at that concentration, not a potency): 31.5%
Estimate against measurement, compound 4: 2.5 percentage points above; the range from low to high includes it.
By their numbers in this assay, from the lowest: compounds 2, 4, 3 and 1 (each within the scatter of the next, the first and the last beyond it).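

In this assay, among these compounds, the first change on the aromatic ring of the benzyl group, methyl in place of hydrogen para to a large group, gives a number 2.1 percentage points lower from compound 3 to compound 4 (within the scatter), so this single added carbon cannot be separated from the unsubstituted benzyl compound. Exchanges at the amine nitrogen in the ring read the same way with the larger 4-methylbenzyl group, with a number 5.7 percentage points higher from compound 2 to compound 4 (within the scatter) and a number 7.1 percentage points lower from compound 1 to compound 4 (within the scatter), so compound 4, like compound 3, cannot be told apart from compound 1 or compound 2, and the step of a number 12.8 percentage points lower from compound 1 to compound 2 (beyond the scatter) remains the only one beyond the scatter. Nothing available bears on why the methyl leaves the read-out within the scatter.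

From the compounds shown here alone, it remains open whether a different group at this para place, such as methoxy, a chlorine atom or a carboxylic acid, would give a step beyond the scatter. The read-out at one concentration also leaves open whether compound 3 and compound 4 would differ in the size of their effect at any other concentration.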